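Carbonyl-linked chain variants: notes toward compound 4

The compounds below may be only part of what the source reports. "The series", "measured", "known", "first", "only" and "open" are said of these compounds alone.

Measured so far in a functional assay on HT-29 cells (Homo sapiens) for antiproliferative activity, read by MTT assay, with a stated time of 48 h; on this read-out higher numbers stand for weaker inhibition and lower numbers for stronger inhibition:
compound 1 `CC(=O)Oc1ccccc1C(=O)NCC[Se]C#N` gives 2100 nM
compound 2 `CC(=O)Oc1ccccc1C(=O)OCC[Se]C#N` gives 30900 nM
compound 3 `CC(=O)Oc1ccccc1C(=O)[Se]CC[Se]C#N` gives 27500 nM

Compound 3 stands second highest of the three numbers. Its nearest neighbour is compound 2, separated by a 1.1-fold lower number from compound 2 to compound 3 (0.05 log units; within the scatter), so no order between compound 2 and compound 3 can be read. Compound 1 is the distant one: a 13-fold higher number from compound 1 to compound 3 (1.12 log units; beyond the scatter), a step well beyond the scatter.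

The next compound, compound 4 `CC(=O)Oc1ccccc1C(=O)NCCSC#N`, differs from compound 3 in one place: a group of 6 heavy atoms (3 carbon, 2 nitrogen, 1 sulfur; no ring) in place of a group of 6 heavy atoms (3 carbon, 1 nitrogen, 2 selenium; no ring), on a carbonyl carbon. Two things change at once here. The chain goes back to the amino linkage seen in compound 1, and sulfur takes the place of selenium at the cyano-bearing end of the chain. The measured step of a 13-fold higher number from compound 1 to compound 3 (1.12 log units; beyond the scatter) bears directly on the first part, read in reverse, and the parallel step a 15-fold higher number from compound 1 to compound 2 (1.17 log units; beyond the scatter) shows the same size for the ester. For the measured compounds named here, no measured pair isolates the second part, the sulfur for selenium exchange, so its contribution is unknown.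

The expectation for compound 4 in this assay is therefore a large fall in the number, close to the reverse of the step from compound 1 to compound 3, with a wide margin for the unmeasured sulfur change. Compound 4 is estimated at 4000 nM, within 1200 nM to 15000 nM, which means an expected step of a 6.9-fold lower number from compound 3 to compound 4 (0.84 log units; beyond the scatter).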

Compound 4, half-maximal inhibitory concentration: > 50000 nM
Compound 4 ended at the assay's limit; the forecaster's own chance of this, stated with the estimate: 5%; at least 12-fold (1.09 log units) between middle value and limit.
By their numbers in this assay, from the lowest: compound 1; then compounds 3 and 2 (each within the scatter of the next). At a limit, above all of these: compound 4.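

In this assay compound 4 yields no number, only a limit of the assay: the limit of > 50000 nM in this assay, at which 1 of the 4 values shown sits.

For the compounds shown here, the step of an at least 23-fold higher number from compound 1 to compound 4 (1.37 log units; beyond the scatter) gives the first measure of the exchange in a pair that differs in one place, sulfur taking the place of selenium at the cyano-bearing end of the chain with the amide-type nitrogen kept. Going by these compounds alone, at this position in this one pair, the selenium compound therefore holds a measurable antiproliferative value and the sulfur compound does not, a large loss that the earlier compounds, all of which carry selenium, could not show. The steps of an at least 1.8-fold higher number from compound 3 to compound 4 (0.25 log units; that floor lies within the scatter) and an at least 1.6-fold higher number from compound 2 to compound 4 (0.20 log units; that floor lies within the scatter) cannot be read, as they offer only a floor within the scatter and those pairs differ in more than one place.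

Still open, going by these compounds, is whether the same exchange has a similar size on the ester-linked chain of compound 2. The compounds shown also say nothing of what a longer chain on the amide-type nitrogen, or a methyl group in place of the nitrile, would give.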